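Replacing 3-bromo-4-methylphenyl with pentyl: compound 3 to compound 4

The compounds below may be only part of what the source reports. "The series", "measured", "known", "first", "only" and "open" are said of these compounds alone.

Values in a functional assay on IMR-32 cells (Homo sapiens) for antiproliferative activity, read by MTT assay (a lower number here means a stronger inhibitor, a higher number a weaker inhibitor), for the measured compounds
- Compound 1 `CC1(C)CCc2c(ccc(C(=O)/C=C/c3ccc(OCc4cn(-c5ccc(Cl)cc5)nn4)cc3)c2O)O1` gives "not active" (no number reported)
- Compound 2 `CC1(C)CCc2c(ccc(C(=O)/C=C/c3ccc(OCc4cn(-c5ccc(Br)cc5)nn4)cc3)c2O)O1` gives 117000 nM
- Compound 3 `Cc1ccc(-n2cc(COc3ccc(/C=C/C(=O)c4ccc5c(c4O)CCC(C)(C)O5)cc3)nn2)cc1Br` gives "not active" (no number reported)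

In this assay compound 3 has no single number. It is recorded as "not active" (no number reported) and compound 1 is the only other entry of that kind. Only compound 2 yields a number at 117000 nM and that number marks a very weak inhibitor.

Compound 4 `CCCCCn1cc(COc2ccc(/C=C/C(=O)c3ccc4c(c3O)CCC(C)(C)O4)cc2)nn1` keeps the shared core and carries pentyl in place of 3-bromo-4-methylphenyl on an aromatic nitrogen so a group with a ring gives way to an open chain. Among the measured compounds shown here, without a number for compound 3, no step can be sized, and no measured compound has an open chain in this place. The expectation in this assay is therefore modest: compound 4 should stay close to compound 2 at 117000 nM with no step beyond the usual scatter, and a report of no activity remains quite possible. Compound 4 is expected at 100000 nM within 30000 nM to 300000 nM if a number is reported at all.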

Compound 4, half-maximal inhibitory concentration: "not active" (no number reported)
Compound 4 has no reported number here; the estimate stays without a comparison.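

In this assay, among the compounds shown here, compound 3 and compound 4 are both recorded as not active, and no step between them can be read. Nothing shown gives a reason for this result. The compounds shown leave open how far pentyl and 3-bromo-4-methylphenyl differ in this place.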